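From Branched to Straight Butyl on a Sulfur

The source may report more compounds than this note shows. Statements on the series, on what has been measured and on what is new or still open speak of the compounds shown alone.

Of the compounds shown here, three have so far been tested in an ADME assay on MCF-10A cells (Homo sapiens) for antiproliferative activity, read by MTT assay, with a stated time of 72 h; a lower number here means a stronger inhibitor, a higher number a weaker inhibitor. Compound 1 `CCC(C)SSC(=S)N(CC)CC` reaches only the edge of the measurement: in this assay compound 1 gives > 10000 nM, which is a limit rather than a number. Compound 2 `S=C(SSC1CCCCC1)N1CCCC1` likewise sits at a limit, giving > 10000 nM in this assay. Compound 3 `S=C(SSC1CCCCC1)N1CCCCC1` gives > 10000 nM in this assay, again a limit. Going by the values given here, no step between the measured compounds can be sized, and compound 1 cannot be placed above or below the other two; what the three share is the limit of > 10000 nM in this assay, at which 3 of the 3 values shown sit.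

Compound 4 `CCCCSSC(=S)N(CC)CC` has not yet been measured. It differs from compound 1 in one place: butyl in place of sec-butyl on a sulfur. The step from compound 1 to compound 4 is expected to be none beyond the scatter, with a step that the limit leaves unreadable from compound 1 to compound 4 as the expected change. Compound 4 is therefore expected to give about 15000 nM in this assay, in an expected range from 5000 nM to 50000 nM, most likely reported once more as a limit.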

Compound 4, half-maximal inhibitory concentration: > 10000 nM
Compound 4: no number, only a limit (the forecaster's own chance of this, stated with the estimate: 85%); the middle value lies beyond the limit too.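

No step from compound 1 to compound 4 can be read, because both results are limits rather than numbers: the limit of > 10000 nM in this assay, at which 4 of the 4 values shown sit.

The compounds shown leave open whether butyl and sec-butyl on a sulfur differ at all in this assay, and what real potency any of these compounds has.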